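A Second Trifluoromethyl Group on the Aryl Ring

A few compounds are considered here, and "the series" means these few. Any claim that something is new, unique, unknown or untested is made for them only; others in the source may bear on it.

Among the measured compounds shown here, compound 1 `Nc1scc(-c2cccc(C(F)(F)F)c2)c1C(=O)c1ccccc1` is the stronger of the two compounds measured so far. In a functional assay on CHO cells for agonist activity at adenosine receptor A1 (Homo sapiens), read by fluorescence and ERK phosphorylation, with stated times of 30 min and 1.5 h, tested at 3 uM (on this read-out higher numbers stand for a stronger effect at the one concentration tested and lower numbers for a weaker effect), compound 1 gives 83%, while compound 2 `Nc1scc(-c2cccc(Cl)c2)c1C(=O)c1ccccc1` gives 45%. For the measured compounds named here, the single known step joins these two: a number 38 percentage points lower from compound 1 to compound 2 (beyond the scatter). Going by the values given here, compound 1 therefore stands highest of the two numbers, with compound 2 as its only neighbour, lying beyond the scatter below it.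

Compound 3 `Nc1scc(-c2cc(C(F)(F)F)cc(C(F)(F)F)c2)c1C(=O)c1ccccc1` differs from compound 1 by trifluoromethyl in place of hydrogen on an aromatic carbon. The entering group sits on an aromatic carbon of a six-membered aromatic ring of carbon only, meta to a trifluoromethyl group. Among the compounds with values here, only one measured step bears on this change, and only indirectly: a number 38 percentage points lower from compound 1 to compound 2 (beyond the scatter), a large loss when chloro replaced trifluoromethyl. Within the data shown here, that step concerns the group already present in compound 1, not the addition of a second one, and no measured pair adds a group at this place. The step is expected to be a number 11 percentage points lower from compound 1 to compound 3 (beyond the scatter), small in either direction and uncertain. Compound 3 is estimated at 72%, between 35% and 95%.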

Compound 3, a percentage reported as activity, at one concentration (the size of the read-out at that concentration, not a potency): 83%
Beside the measured number, compound 3's estimate is 11 percentage points below it; low and high end bracket the measured number.
By their numbers in this assay, from the lowest: compound 2; then compounds 1 and 3 (each within the scatter of the next).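

Adding trifluoromethyl at this aromatic carbon, meta to a trifluoromethyl group, gives no change at the digits printed from compound 1 to compound 3 (within the scatter) in this assay. The earlier step, a number 38 percentage points lower from compound 1 to compound 2 (beyond the scatter), showed only what happened when the group already on the ring was exchanged, whereas this result shows that the ring can also take a second trifluoromethyl group, with 4 more heavy atoms, and the read-out stays within the scatter. No measurement shown here explains why the read-out holds at this place.

A reading at one concentration is not a potency, so compound 1 and compound 3 may still differ in a way that this read-out does not reveal, and the data cannot say whether the second trifluoromethyl group contributes anything or is merely accepted. As far as these compounds go, it also remains open how the same aromatic carbon would respond to a different kind of group, such as an amine, a carboxylic acid or a methoxy group, and whether a chloro group there would be accepted alongside the first trifluoromethyl group.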